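The source may report more compounds than this note shows. Statements on the series, on what has been measured and on what is new or still open speak of the compounds shown alone.

In an assay for binding affinity to dual specificity mitogen-activated protein kinase kinase 4 (Homo sapiens), read by KINOMEscan, tested at 100 nM (on this read-out higher numbers stand for a weaker effect at the one concentration tested and lower numbers for a stronger effect), compound 3 `CCCS(=O)(=O)Nc1ccc(F)c(C(=O)c2n[nH]c3ncc(-c4ccc(N(C)C)cc4)cc23)c1F` gives 2.5%, the second highest of three numbers. Compound 2 `CCCS(=O)(=O)Nc1ccc(F)c(C(=O)c2n[nH]c3ncc(-c4ccc(N)cc4)cc23)c1F` gives 0.1% and compound 1 `CCCS(=O)(=O)Nc1ccc(F)c(C(=O)c2n[nH]c3ncc(-c4ccccc4Cl)cc23)c1F` gives 9.3%. The steps of a number 6.8 percentage points lower from compound 1 to compound 3 (within the scatter) and a number 2.4 percentage points higher from compound 2 to compound 3 (within the scatter) both lie within the scatter, so nothing separates the three compounds on these numbers. Compound 4 `CCCS(=O)(=O)Nc1ccc(F)c(C(=O)c2n[nH]c3ncc(-c4ccc(S(=O)(=O)NC)cc4)cc23)c1F` differs from compound 3 on the same aromatic carbon: methylsulfamoyl in place of dimethylamino on an aromatic carbon. The earlier changes on that aromatic carbon bear on it, namely a number 9.2 percentage points lower from compound 1 to compound 2 (within the scatter) and a number 6.8 percentage points lower from compound 1 to compound 3 (within the scatter), and each stayed within the scatter. The step of a number 0.5 percentage points higher from compound 3 to compound 4 (within the scatter) in this assay is therefore expected to be small, with no direction beyond the scatter. Compound 4 is estimated at 3%, with a range from 0% to 12%.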

Compound 4, a percentage reported as activity, at one concentration (the size of the read-out at that concentration, not a potency): 1.2%
Beside the measured number, compound 4's estimate is 1.8 percentage points above it, within the range that was stated.
By their numbers in this assay, from the lowest: compounds 2, 4, 3 and 1 (each within the scatter of the next).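

In this assay, methylsulfamoyl, para to a large group on this aromatic carbon, gives a number 1.3 percentage points lower from compound 3 to compound 4 (within the scatter) and a number 1.1 percentage points higher from compound 2 to compound 4 (within the scatter), so replacing dimethylamino or amino with this larger group of 5 heavy atoms does not separate the compounds. The wider change gives a number 8.1 percentage points lower from compound 1 to compound 4 (within the scatter) and likewise leaves compound 4 unseparated from compound 1. No evidence here points to a cause.

Going by these compounds, whether a carboxylic acid or morpholine on this carbon, or a longer chain in place of the methyl of methylsulfamoyl, would give a step beyond the scatter remains open.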